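Moving the methoxy: from one ring substituent to two

The compounds below may be only part of what the source reports. "The series", "measured", "known", "first", "only" and "open" are said of these compounds alone.

Of the compounds shown here, three sharing one core have been measured in an assay on isolated protein for inhibition of glutathione S-transferase Mu 2 (Homo sapiens), with a stated time of 10 min; on this read-out lower numbers stand for stronger inhibition and higher numbers for weaker inhibition. Compound 1 `O=C(CCC(=O)OCCCCCCSc1ccc([N+](=O)[O-])c2nonc12)Nc1ccccc1` gives 700 nM. Compound 2 `COc1ccccc1NC(=O)CCC(=O)OCCCCCCSc1ccc([N+](=O)[O-])c2nonc12` gives 280 nM, and compound 3 `O=C(CCC(=O)OCCCCCCSc1ccc([N+](=O)[O-])c2nonc12)Nc1ccc(F)cc1` gives 320 nM. Compound 2 stands at the low end of these numbers, but compound 3 lies within the scatter of it, as the step of a 1.1-fold higher number from compound 2 to compound 3 (0.06 log units; within the scatter) shows; only compound 1 is clearly apart, with a 2.5-fold lower number from compound 1 to compound 2 (0.40 log units; beyond the scatter) and a 2.2-fold lower number from compound 1 to compound 3 (0.34 log units; beyond the scatter).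

Compound 4 `COc1ccc(NC(=O)CCC(=O)OCCCCCCSc2ccc([N+](=O)[O-])c3nonc23)cc1OC` differs from compound 2 by 3,4-dimethoxyphenyl in place of 2-methoxyphenyl on an amide-type nitrogen. Among the compounds with values here, no measured step covers this change directly. The two steps that added a single substituent to the bare ring, a 2.5-fold lower number from compound 1 to compound 2 (0.40 log units; beyond the scatter) and a 2.2-fold lower number from compound 1 to compound 3 (0.34 log units; beyond the scatter), were both modest, and the swap of one substituted ring for another, a 1.1-fold higher number from compound 2 to compound 3 (0.06 log units; within the scatter), stayed within the scatter. On that basis the step from compound 2 to compound 4 in this assay is expected to be a 1.1-fold higher number from compound 2 to compound 4 (0.06 log units; within the scatter), that is, no change beyond the scatter. Compound 4 is therefore estimated at 320 nM, within 130 nM to 800 nM.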

Compound 4, half-maximal inhibitory concentration: 360 nM
The estimate for compound 4 lay 1.1-fold (0.05 log units) below the measured number, within the range that was stated.
By their numbers in this assay, from the lowest: compounds 2, 3, 4 and 1 (each within the scatter of the next, the first and the last beyond it).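

In this assay, the 3,4-dimethoxyphenyl group on the amide-type nitrogen, with 10 heavy atoms against 8 in 2-methoxyphenyl, stays within the scatter of both singly substituted rings (a 1.3-fold higher number from compound 2 to compound 4 (0.11 log units; within the scatter); a 1.1-fold higher number from compound 3 to compound 4 (0.05 log units; within the scatter)), so this position accepts a second methoxy with no change that can be read. Unlike compound 2 and compound 3, however, compound 4 is not clearly apart from the bare phenyl of compound 1 (a 1.9-fold lower number from compound 1 to compound 4 (0.29 log units; within the scatter)), so the separation seen with one substituent does not carry over to this pair of methoxy groups. Nothing available explains this result.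

The compounds shown leave open whether an amine or a carboxylic acid on the ring, or a benzyl group in place of the ring, would move the number beyond the scatter. Nor can these numbers tell which of the two methoxy groups matters, if either does.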